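Methyl for Methoxy on a Second Core

The compounds below may be only part of what the source reports. "The series", "measured", "known", "first", "only" and "open" are said of these compounds alone.

Compound 1 `COc1ccnc(C[S+]([O-])c2nc3cc(OCC(F)(F)F)ccc3[nH]2)c1OC`: 0.183 h
Compound 2 `COc1ccnc(C[S+]([O-])c2nc3cc(OCC(F)(F)F)ccc3[nH]2)c1C`: 0.0833 h
Compound 3 `COc1cc2[nH]c([S+]([O-])Cc3nccc(OC)c3OC)nc2cc1OC(F)F`: 0.25 h

In an ADME assay, at pH 3 (on this read-out higher numbers stand for a longer-lived compound and lower numbers for a shorter-lived compound), compound 1 gives 0.183 h, compound 2 gives 0.0833 h and compound 3 gives 0.25 h. The difference between the core of compound 1 and the core of compound 3 is not broken down here. Compound 3 and compound 1 lie within the scatter of each other; compound 2 lies beyond it from both. From compound 1 to compound 2 the change is methyl in place of methoxy on an aromatic carbon, which gave a 2.2-fold lower number from compound 1 to compound 2 (0.34 log units; beyond the scatter). Compound 4 `COc1cc2[nH]c([S+]([O-])Cc3nccc(OC)c3C)nc2cc1OC(F)F` awaits measurement in this assay; the change from compound 3 is methyl in place of methoxy on an aromatic carbon, the same change, its place described in identical words. Compound 4 is expected to show a 2.3-fold lower number from compound 3 to compound 4 (0.36 log units; beyond the scatter), resting on a 2.2-fold lower number from compound 1 to compound 2 (0.34 log units; beyond the scatter). Compound 4 is estimated at 0.11 h, between 0.05 h and 0.25 h.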

Compound 4, half-life: 0.1 h
The estimate for compound 4 lay 1.1-fold (0.04 log units) above the measured number; the measured number falls inside the stated range.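

In this assay, methyl in place of methoxy on an aromatic carbon gave a 2.5-fold lower number from compound 3 to compound 4 (0.40 log units; beyond the scatter), so the change lowered the number on the core of compound 3 as well. Set beside the earlier step, the size of the change carried over from one core to the other: the same change on two cores in this assay, a 2.2-fold lower number (0.34 log units; beyond the scatter) from compound 1 to compound 2 and a 2.5-fold lower number (0.40 log units; beyond the scatter) from compound 3 to compound 4, 1.1-fold (0.06 log units) apart, within the scatter of two such steps. For the compounds shown here, this rests on only one pair of compounds on each of these cores and on this single assay, so it does not show that the change would carry over to other cores or explain the lower numbers.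

The compounds shown leave open how an ethyl group or a chlorine atom would behave in place of the methoxy group. They also leave open whether an amine on the core would alter the step.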